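A few compounds are considered here, and "the series" means these few. Any claim that something is new, unique, unknown or untested is made for them only; others in the source may bear on it.

Of the compounds shown here, three sharing one core have been tested in a functional assay on KB cells (Homo sapiens) for antiproliferative activity, read by sulforhodamine B assay, with a stated time of 3 days; on this read-out lower numbers stand for an effect already at smaller amounts and higher numbers for an effect only at larger amounts of compound. Compound 1 `CCC1=C(O)c2c(oc(-c3ccc(CC(C)C)cc3)cc2=O)C(CC)(CC)C1=O`, which carries isobutyl on an aromatic carbon, gives 29.3 uM. Compound 2 `CCC1=C(O)c2c(oc(-c3ccc(C(F)(F)F)cc3)cc2=O)C(CC)(CC)C1=O`, with trifluoromethyl there, gives 35.7 uM. Compound 3 `CCC1=C(O)c2c(oc(-c3ccc(F)cc3)cc2=O)C(CC)(CC)C1=O`, with fluoro there, gives 33 uM. Compound 3 thus lies within the scatter of both other compounds, so no order can be read among the three.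

The next compound is compound 4 `CCC1=C(O)c2c(oc(-c3ccccc3OC)cc2=O)C(CC)(CC)C1=O`, which has 2-methoxyphenyl in place of the 4-fluorophenyl of compound 3, on an aromatic carbon next to the ring oxygen (2-methoxyphenyl in place of 4-fluorophenyl on an aromatic carbon).

The measured steps that bear on this change are those that swapped the group on the phenyl ring: a 1.2-fold higher number from compound 1 to compound 2 (0.09 log units; within the scatter), a 1.1-fold higher number from compound 1 to compound 3 (0.05 log units; within the scatter) and a 1.1-fold lower number from compound 2 to compound 3 (0.03 log units; within the scatter). All three stay within the scatter, so these swaps left the number in this assay practically unmoved. Going by the values given here, none of the measured compounds carries a 2-methoxyphenyl group, however, so this change goes beyond what those steps have tried, and the range has to stay wide. Even so, no shift beyond the scatter is expected in either direction. The expected result is a 1.1-fold lower number from compound 3 to compound 4 (0.04 log units; within the scatter). For compound 4 the estimated value is 30 uM, with an expected range from 15 uM to 60 uM.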

Compound 4, concentration for half-maximal effect: 40.8 uM
For compound 4 the middle estimate is 1.4-fold (0.13 log units) below the measured one; the range from low to high includes it.
By their numbers in this assay, from the lowest: compounds 1, 3, 2 and 4 (each within the scatter of the next).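

The step from 4-fluorophenyl to 2-methoxyphenyl, on the aromatic carbon next to the ring oxygen, gives a 1.2-fold higher number from compound 3 to compound 4 (0.09 log units; within the scatter) in this assay. The earlier swaps exchanged one group for another on the phenyl ring, whereas this one changes both the group and its place on that ring, and the number still does not move beyond the scatter, so the insensitivity seen so far now extends to a second place on the phenyl ring. No measurement among these data speaks to the reason for this flat result.

Going by these compounds, all four compounds carry a substituted phenyl ring on this carbon, so it remains open whether something else there, such as a pyridine ring, or a phenyl ring bearing an amine or a carboxylic acid, would shift the number beyond the scatter. On these data alone, it is also open whether changes elsewhere on the shared core, for example a longer chain in place of the ethyl groups, would move the number where these swaps on the phenyl ring did not.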